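Shrinking the Carbonyl Substituent: From tert-Butoxy to Methyl

The source may report more compounds than this note shows. Statements on the series, on what has been measured and on what is new or still open speak of the compounds shown alone.

For the measured compounds named here, the three compounds measured so far share one core and differ only in the group on a carbonyl carbon. Compound 2 `CC(C)(C)OC(=O)NCCS(=O)(=O)NC(=O)c1ccc(Nc2nc(NC3(c4ccc(Cl)cc4)CC3)nc(OCC(F)(F)F)n2)cc1` carries a tert-butoxy there, and in a physicochemical assay for permeability, using PAMPA, at pH 7.4 (on this read-out higher numbers stand for higher permeability and lower numbers for lower permeability), compound 2 gives 111 nm/s, the highest of the three numbers. Compound 1 `CC(C)(C)NC(=O)NCCS(=O)(=O)NC(=O)c1ccc(Nc2nc(NC3(c4ccc(Cl)cc4)CC3)nc(OCC(F)(F)F)n2)cc1` carries a (tert-butyl)amino instead and gives 49 nm/s, while compound 3 `CC(C)C(=O)NCCS(=O)(=O)NC(=O)c1ccc(Nc2nc(NC3(c4ccc(Cl)cc4)CC3)nc(OCC(F)(F)F)n2)cc1` carries an isopropyl and gives 13 nm/s. The steps are all beyond the scatter: a 2.3-fold higher number from compound 1 to compound 2 (0.36 log units; beyond the scatter), a 3.8-fold lower number from compound 1 to compound 3 (0.58 log units; beyond the scatter) and an 8.5-fold lower number from compound 2 to compound 3 (0.93 log units; beyond the scatter).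

Compound 4 `CC(=O)NCCS(=O)(=O)NC(=O)c1ccc(Nc2nc(NC3(c4ccc(Cl)cc4)CC3)nc(OCC(F)(F)F)n2)cc1` has not yet been measured in this assay. It differs from compound 2 as follows: methyl in place of tert-butoxy on a carbonyl carbon. Going by the values given here, the step that bears most directly on it is the one from compound 2 to compound 3, where a tert-butoxy gave way to an isopropyl and the number fell an 8.5-fold lower number from compound 2 to compound 3 (0.93 log units; beyond the scatter). Here the group entering is even smaller than isopropyl, with no acceptor, so a drop of at least that size is expected, namely a 16-fold lower number from compound 2 to compound 4 (1.20 log units; beyond the scatter). Compound 4 is therefore estimated at 7 nm/s, with a range from 2 nm/s to 25 nm/s.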

Compound 4, apparent permeability: 7 nm/s
Estimate against measurement, compound 4: no gap at the digits printed; the range from low to high includes it.
By their numbers in this assay, from the lowest: compounds 4 and 3 (each within the scatter of the next); then compound 1; then compound 2.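

In this assay, for the compounds shown here, putting methyl in place of tert-butoxy on this carbonyl carbon gives a 16-fold lower number from compound 2 to compound 4 (1.20 log units; beyond the scatter), the only step at this position so far that is rated large, and the comparison with the (tert-butyl)amino group gives a 7.0-fold lower number from compound 1 to compound 4 (0.85 log units; beyond the scatter). Methyl and isopropyl cannot be told apart here, with a 1.9-fold lower number from compound 3 to compound 4 (0.27 log units; within the scatter), so among these four compounds the two groups containing a tert-butyl, in compound 1 and compound 2, stand clear above the two plain carbon groups, in compound 3 and compound 4, and none of the four goes against this. No measurement shown explains why the groups separate in this way.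

Still open, on these data alone, is what a tert-butyl attached directly to the carbonyl carbon would give, which would show whether the higher numbers go with the tert-butyl itself or with the oxygen or nitrogen joining it to the carbonyl. A methoxy or a methylamino group in the same place would put that question the other way round, keeping the joining atom while losing the tert-butyl.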